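Thiophen-2-yl in place of 4-bromophenyl in compound 1

The source may hold more compounds than are shown below. What is called first, only, known or untested is meant among the compounds shown, and "the series" means these compounds.

Compound 1 `C=C(Br)C(=O)Nc1ccc(/C=C/C(=O)c2ccc(Br)cc2)cc1` gives 1100 nM in a functional assay on FM3A cells (Mus musculus) for antiproliferative activity, with a stated time of 48 h (a higher number here means a weaker inhibitor, a lower number a stronger inhibitor), and is one of three measured compounds. Compound 2 `C=C(Br)C(=O)Nc1ccc(/C=C/C(=O)c2ccc(OCC)cc2)cc1` gives 680 nM and lies within the scatter of compound 1. Compound 3 `C=C(Br)C(=O)Nc1ccc(/C=C/C(=O)c2cccc3ccccc23)cc1` gives 2400 nM as the highest of the three numbers and lies beyond the scatter of compound 1. Compound 1 therefore stands with compound 2 at the lower end of this small set.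

Compound 4 `C=C(Br)C(=O)Nc1ccc(/C=C/C(=O)c2cccs2)cc1` is not yet measured and carries thiophen-2-yl in place of 4-bromophenyl on a carbonyl carbon. Among the measured compounds shown here, no measured compound carries thiophen-2-yl, so no measured step covers this change directly. For the measured compounds named here, the only measured single change is ethoxy in place of bromo, at a 1.6-fold lower number from compound 1 to compound 2 (0.21 log units; within the scatter) and so without a resolved effect. Compound 3 at 2400 nM shows that a different group on the carbonyl carbon can sit beyond the scatter of compound 1, which gives a slight lean towards a higher number. No shift beyond the scatter is expected in this assay overall. The expected step is a 1.1-fold higher number from compound 1 to compound 4 (0.04 log units; within the scatter) and remains a rough expectation. Compound 4 is estimated at 1200 nM with an expected range from 500 nM to 2800 nM for the measurement.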

Compound 4, half-maximal inhibitory concentration: 520 nM
Beside the measured number, compound 4's estimate is 2.3-fold (0.36 log units) above it, within the range that was stated.
By their numbers in this assay, from the lowest: compounds 4, 2 and 1 (each within the scatter of the next, the first and the last beyond it); then compound 3.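

In this assay, among the compounds shown here, thiophen-2-yl in place of 4-bromophenyl on the carbonyl carbon gives the first resolved single change at this position, with a 2.1-fold lower number from compound 1 to compound 4 (0.33 log units; beyond the scatter), while ethoxy in place of bromo gave only a 1.6-fold lower number from compound 1 to compound 2 (0.21 log units; within the scatter) on the same ring. The 4-bromophenyl group is therefore not needed to keep activity here: a five-membered aromatic ring with 1 hetero atom can take its place on the shared core, and the step is modest but points to a lower number, opposite to what the naphthalene-bearing compound 3 at 2400 nM might have suggested for a change of ring. Compound 4 and compound 2 lie within the scatter of each other, so neither can be placed ahead, and nothing shown explains the lower number of compound 4.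

Open, going by these compounds, is whether the result belongs to the sulfur atom, to the five-membered ring or to the attachment point, which furan-2-yl or thiophen-3-yl on the same carbonyl carbon would separate. Also open, on these data alone, is how far the position accepts other rings, such as pyridin-3-yl, or substituted thiophenes such as a 5-chlorothiophen-2-yl group.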